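The source may report more compounds than this note shows. Statements on the series, on what has been measured and on what is new or still open speak of the compounds shown alone.

Values in a functional assay on KB-V1 cells (Homo sapiens) for cytotoxicity, read by MTT assay, with a stated time of 72 h; on this read-out higher numbers stand for weaker inhibition and lower numbers for stronger inhibition:
- Compound 1 `O=C1Nc2ccccc2/C1=N/NC(=S)Nc1cccnc1`: > 50000 nM, a limit of the assay
- Compound 2 `O=C1Nc2ccccc2/C1=N/NC(=S)NCc1ccccc1`: 7630 nM
- Compound 3 `C=CCNC(=S)N/N=C1\C(=O)Nc2ccccc21`: 20700 nM

Of the two actual numbers in this assay, compound 3 at 20700 nM holds the higher, and compound 2 sits lower at 7630 nM. Compound 4 `CC(C)NC(=S)N/N=C1\C(=O)Nc2ccccc21` carries isopropyl in place of allyl on an amide-type nitrogen. Two measured steps change the group on that nitrogen, a 2.7-fold higher number from compound 2 to compound 3 (0.43 log units; beyond the scatter) and an at least 2.4-fold lower number from compound 1 to compound 3 (0.38 log units; beyond the scatter), each beyond the scatter. Both replace a ring-bearing group with allyl, whereas here neither group has a ring, so no step beyond the scatter is expected in this assay. The expected step is a 1.0-fold lower number from compound 3 to compound 4 (0.01 log units; within the scatter). For compound 4 the estimated value is 20000 nM, with an expected range from 9000 nM to 45000 nM.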

Compound 4, half-maximal inhibitory concentration: 10300 nM
Beside the measured number, compound 4's estimate is 1.9-fold (0.29 log units) above it; low and high end bracket the measured number.
By their numbers in this assay, from the lowest: compounds 2, 4 and 3 (each within the scatter of the next, the first and the last beyond it). At a limit, above all of these: compound 1.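

In this assay, isopropyl on this amide-type nitrogen gives a 2.0-fold lower number from compound 3 to compound 4 (0.30 log units; within the scatter) and a 1.3-fold higher number from compound 2 to compound 4 (0.13 log units; within the scatter), so among these compounds, a group with no ring falls within the scatter of benzyl, even though allyl and benzyl differ beyond it. Pyridin-3-yl stands apart, with an at least 4.8-fold lower number from compound 1 to compound 4 (0.68 log units; beyond the scatter), the only one of the three new steps beyond the scatter. The value of compound 1 is a limit of the assay: the limit of > 50000 nM in this assay, at which 1 of the 4 values shown sits.

On these data alone, it remains open whether a longer chain, such as n-butyl, or a chain carrying an amine would keep this level on the same nitrogen.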